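Nitro Substitution on a Urea and Its Thiourea Counterpart

The source may hold more compounds than are shown below. What is called first, only, known or untested is meant among the compounds shown, and "the series" means these compounds.

Three compounds have been measured in a functional assay on A549 cells (Homo sapiens) for antiproliferative activity, read by MTT assay, with a stated time of 48 h; on this read-out higher numbers stand for weaker inhibition and lower numbers for stronger inhibition:
Compound 1, `O=C(Nc1ccccc1)Nc1cccc(NC(=O)c2ccccn2)c1`, gives 5190 nM.
Compound 2, `O=C(Nc1ccc([N+](=O)[O-])cc1)Nc1cccc(NC(=O)c2ccccn2)c1`, gives 320 nM.
Compound 3, `O=C(Nc1cccc(NC(=S)Nc2ccccc2)c1)c1ccccn1`, gives 4400 nM.

Compound 1 and compound 2 differ in one place: nitro in place of hydrogen on an aromatic carbon. This single change brought a 16-fold lower number from compound 1 to compound 2 (1.21 log units; beyond the scatter) in this assay, a large step that lies well beyond the scatter. Compound 3 carries a different core from compound 1; the difference between the two cores is not broken down here. In this assay the values of compound 1 and compound 3 lie within the scatter of each other, so nothing can be said of an order between them.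

Compound 4, `O=C(Nc1cccc(NC(=S)Nc2ccc([N+](=O)[O-])cc2)c1)c1ccccn1`, has not yet been measured in this assay. It differs from compound 3 by nitro in place of hydrogen on an aromatic carbon, the same change that separates compound 1 from compound 2, at the same kind of place. Because this change gave a 16-fold lower number from compound 1 to compound 2 (1.21 log units; beyond the scatter), a step of comparable size is expected when it is applied to compound 3. Compound 4 is therefore expected to give 350 nM in this assay, which would be a step of a 13-fold lower number from compound 3 to compound 4 (1.10 log units; beyond the scatter). The value of compound 4 is expected to fall between 120 nM and 1500 nM, allowing for a somewhat smaller or larger step than the one seen before.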

Compound 4, half-maximal inhibitory concentration: 450 nM
For compound 4 the middle estimate is 1.3-fold (0.11 log units) below the measured one; measured number inside the range.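

In this assay, the change from phenyl to 4-nitrophenyl on the core of compound 3 gave a 9.8-fold lower number from compound 3 to compound 4 (0.99 log units; beyond the scatter), so the large drop in the number seen on the core of compound 1 recurred on a second core. The two steps cannot be told apart in size, and the change therefore carried across these two cores without a measurable loss or gain: the same change on two cores in this assay, a 16-fold lower number (1.21 log units; beyond the scatter) from compound 1 to compound 2 and a 9.8-fold lower number (0.99 log units; beyond the scatter) from compound 3 to compound 4, 1.7-fold (0.22 log units) apart, within the scatter of two such steps

This shows a transfer only for this one pair of cores, for this one place on the ring and in this one cell line, and it neither explains the step nor shows that it would hold on any further core.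

The compounds shown leave open whether another group at the same place, such as an amine, a carboxylic acid or a chlorine atom, would give a step of like size. They also leave open whether nitro at another place on that ring would do the same on either core.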